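A Hydroxy Added to Compound 2

The source may hold more compounds than are shown below. What is called first, only, known or untested is meant among the compounds shown, and "the series" means these compounds.

In a functional assay on MCF7 cells (Homo sapiens) for cytotoxicity, read by MTT assay, with a stated time of 6 days (a higher number here means that more compound is needed for the effect, a lower number that less compound is needed), compound 1 `COc1cc(-c2cc(=O)c3ccc(O)cc3o2)cc(OC)c1OC` reaches only a limit, > 25 ug/mL. Going by the values given here, compound 2 `COc1cc(-c2cc(=O)c3ccc(O)cc3o2)cc(OC)c1O[Si](C)(C)C(C)(C)C` gives 4.47 ug/mL, the only actual number so far. Among the compounds with values here, the single measured step is an at least 5.5-fold lower number from compound 1 to compound 2 (0.74 log units; beyond the scatter). Compound 3 `COc1cc(-c2cc(=O)c3ccc(O)c(O)c3o2)cc(OC)c1O[Si](C)(C)C(C)(C)C` differs from compound 2 by hydroxy in place of hydrogen on an aromatic carbon, ortho to a hydroxy group. Within the data shown here, the measured step concerns a change at another place, and no measured step shows what this hydroxy does. In this assay the expected result is therefore a 1.1-fold higher number from compound 2 to compound 3 (0.05 log units; within the scatter), with no shift beyond the scatter anticipated. For compound 3 the estimated value is 5 ug/mL, within a range from 1.5 ug/mL to 18 ug/mL.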

Compound 3, concentration for half-maximal effect: 0.31 ug/mL
Beside the measured number, compound 3's estimate is 16-fold (1.21 log units) above it; measured number below the stated range.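

Going by these compounds alone, until now, the only measured change lay at another place. This position, an aromatic carbon ortho to a hydroxy group, now proves highly responsive in this assay: hydroxy in place of hydrogen gives a 14-fold lower number from compound 2 to compound 3 (1.16 log units; beyond the scatter). Nothing measured here explains this step.

From the compounds shown here alone, whether the step needs hydroxy itself stays open, since a methoxy, an amine or a fluorine on this carbon would test that. Also open, going by these compounds, is whether the same hydroxy would act in compound 1, which lacks the silicon-bearing group.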